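This account rests on a few compounds, and the source may have more. Where it says the series, first, only, none or still open, it means among the compounds named here.

Compound 1 `COc1cc(NC(C)CCCNC(=O)Nc2ccc(C(F)(F)F)cc2)c2ncccc2c1`: 20000 nM
Compound 2 `COc1cc(NC(C)CCCNC(=O)NNC(=O)Nc2cccc(C(F)(F)F)c2)c2ncccc2c1`: 36000 nM

Both values come from a functional assay on MOLT-4 cells (Homo sapiens) for inhibition, read by MTT assay, with a stated time of 72 h (a higher number here means a weaker inhibitor, a lower number a stronger inhibitor), where these two compounds need high concentrations to reach the half-maximal effect. Compound 2, at 36000 nM, lies within the usual scatter of compound 1, at 20000 nM, so repeated measurements could not reliably separate them. Going by the values given here, they also differ in more than one place, and no measured pair isolates a single structural change.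

The next compound, compound 3 `COc1cc(NC(C)CCCNC(=O)NNC(=O)Nc2cccc(Cl)c2)c2ncccc2c1`, keeps the structure of compound 2 except for one substituent: chloro in place of trifluoromethyl on an aromatic carbon. The change sits on a six-membered aromatic ring of carbon only, meta to a large group. Among the compounds with values here, no measured pair shows this swap, so the expectation rests only on the two values in hand. Neither suggests a large change in this assay, and no step beyond the scatter is expected. The estimated step is a 1.2-fold lower number from compound 2 to compound 3 (0.08 log units; within the scatter). Compound 3 is expected at 30000 nM, with an estimated range from 12000 nM to 70000 nM.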

Compound 3, half-maximal inhibitory concentration: 93000 nM
The estimate for compound 3 lay 3.1-fold (0.49 log units) below the measured number, and the stated range ends below it.
By their numbers in this assay, from the lowest: compounds 1 and 2 (each within the scatter of the next); then compound 3.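

In this assay, replacing trifluoromethyl with chloro on this aromatic carbon gives a 2.6-fold higher number from compound 2 to compound 3 (0.41 log units; beyond the scatter), so the group at this position does affect the read-out, and here chloro gives the weaker inhibitor. The larger exchange, ((3-chlorophenyl)carbamoyl)amino in place of 4-(trifluoromethyl)phenyl on an amide-type nitrogen, gives a 4.7-fold higher number from compound 1 to compound 3 (0.67 log units; beyond the scatter), which separates the new compound from two compounds whose values could not be told apart. No independent measurement is available to explain why either step occurs.

This is a single swap on a single background, so it sets no general rule for the position, and all three compounds still need high concentrations to reach the half-maximal effect. As far as these compounds go, it remains open how a fluoro, methyl, methoxy or nitrile group on the same aromatic carbon would compare with trifluoromethyl and chloro, and whether chloro in place of trifluoromethyl would give a similar step in the framework of compound 1.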